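This account rests on a few compounds, and the source may have more. Where it says the series, first, only, none or still open, it means among the compounds named here.

In an ADME assay on L6 cells (Rattus norvegicus) for cytotoxicity, read by resazurin assay, with a stated time of 72 h (on this read-out higher numbers stand for weaker inhibition and lower numbers for stronger inhibition), compound 1 `N=C(N)c1cc(I)c(OCc2cccc([N+](=O)[O-])c2)c(I)c1` gives 7720000 nM, compound 3 `N=C(N)c1cccc(COc2c(I)cc(C(=N)N)cc2I)c1` gives 19300000 nM, and compound 2 `N=C(N)c1cccc(COc2cccc([N+](=O)[O-])c2)c1` gives 104000000 nM, the highest of the three numbers. Compound 3 is obtained from compound 1 by one change, (a group of 3 heavy atoms (1 carbon, 2 nitrogen; no ring) in place of a group of 3 heavy atoms (1 nitrogen, 2 oxygen; no ring), on an aromatic carbon), and this change brought a 2.5-fold higher number from compound 1 to compound 3 (0.40 log units; beyond the scatter). The difference between the cores of compound 1 and compound 2 is not broken down here. Compound 4 `N=C(N)c1cccc(COc2cccc(C(=N)N)c2)c1` has not yet been tested in this assay. It arises from compound 2 through (a group of 3 heavy atoms (1 carbon, 2 nitrogen; no ring) in place of a group of 3 heavy atoms (1 nitrogen, 2 oxygen; no ring), on an aromatic carbon), the same change as from compound 1 to compound 3, on the same kind of place. For the measured compounds named here, for compound 4 in this assay a step of a 1.9-fold higher number from compound 2 to compound 4 (0.28 log units; within the scatter) is expected, resting on the single earlier instance of this change, because from compound 1 to compound 3 it gave a 2.5-fold higher number from compound 1 to compound 3 (0.40 log units; beyond the scatter). Since this rests on one pair only, the expectation is loose, and the estimate for compound 4 is 200000000 nM, with a range from 80000000 nM to 500000000 nM.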

Compound 4, half-maximal inhibitory concentration: 24000000 nM
The estimate for compound 4 lay 8.3-fold (0.92 log units) above the measured number; measured number outside the range, below it.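

Swapping the nitro group for the incoming group of carbon and nitrogen atoms on the core of compound 2 gave a 4.3-fold lower number from compound 2 to compound 4 (0.64 log units; beyond the scatter) in this assay, the opposite direction to the earlier case. The swap therefore did not carry over from one core to the other with a fixed size or even a fixed direction: the same change on two cores in this assay, a 2.5-fold higher number (0.40 log units; beyond the scatter) from compound 1 to compound 3 and a 4.3-fold lower number (0.64 log units; beyond the scatter) from compound 2 to compound 4, 11-fold (1.03 log units) apart, beyond the scatter of two such steps This shows that, for these two pairs, the result of the swap depends on the core that carries it, but two pairs cannot show which feature of the cores matters or how the swap would behave on any other core.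

As far as these compounds go, the iodine atoms in compound 1 and compound 3 are only one of the differences between the two cores, so their part in the reversal remains open. Also open, from the compounds shown here alone, is how a different group in the nitro position, such as an amine or a carboxylic acid, would shift the number on each core.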